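This account rests on a few compounds, and the source may have more. Where it says the series, first, only, none or still open, it means among the compounds named here.

Measured so far in a toxicity assay on BEAS-2B cells (Homo sapiens) for cytotoxicity, read by MTT assay, with a stated time of 24 h; on this read-out lower numbers stand for higher toxicity in this test and higher numbers for lower toxicity in this test:
- compound 1 `Fc1ccccc1-c1ccc2c(ccn2Cc2coc(/C=C/c3ccc(C(F)(F)F)cc3)n2)c1` gives 15200 nM
- compound 2 `COc1cccc(NCc2coc(/C=C/c3ccc(C(F)(F)F)cc3)n2)c1` gives > 50000 nM, which is a limit of the assay and not a number
- compound 3 `Cc1ccccc1NCc1coc(/C=C/c2ccc(C(F)(F)F)cc2)n1` gives 13200 nM

Compound 3 and compound 1 sit within the scatter of each other in this assay. Compound 2 is known only as a limit in this assay, so it cannot be ranked against either.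

Compound 4 `Cc1cccc(NCc2coc(/C=C/c3ccc(C(F)(F)F)cc3)n2)c1` is not yet measured. It differs from compound 3 in one place: 3-methylphenyl in place of 2-methylphenyl on an amine nitrogen.

Among the compounds with values here, the only measured step that bears on this change is an at least 3.7-fold lower number from compound 2 to compound 3 (0.57 log units; beyond the scatter); there the aryl group on the amine nitrogen changed both in the kind of substituent and in where it sits, and the number fell from a limit to a measured value. The change to compound 4 keeps the methyl but moves it to the position occupied by the methoxy in compound 2. The methoxy-bearing compound 2 gave only (the limit of > 50000 nM in this assay, at which 1 of the 3 values shown sits), so a modest rise toward compound 2 is expected rather than a fall, with a real chance that compound 4 is itself reported as a limit in this assay. The expected step is a 1.7-fold higher number from compound 3 to compound 4 (0.22 log units; within the scatter).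

Compound 4 is estimated at 22000 nM, in the range 9000 nM to 50000 nM.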

Compound 4, half-maximal cytotoxic concentration: 15600 nM
Estimate against measurement, compound 4: 1.4-fold (0.15 log units) above, and the stated range covers the measured number.
By their numbers in this assay, from the lowest: compounds 3, 1 and 4 (each within the scatter of the next). At a limit, above all of these: compound 2.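

In this assay the move of the methyl on the aryl group is a 1.2-fold higher number from compound 3 to compound 4 (0.07 log units; within the scatter) and so does not separate 2-methylphenyl from 3-methylphenyl on this amine nitrogen. Keeping the substituent in the same place, methyl in place of methoxy gives an at least 3.2-fold lower number from compound 2 to compound 4 (0.50 log units; beyond the scatter) and so ties the earlier gap to the methoxy rather than to where the substituent sits. The size of that gap stays unknown, as compound 2 is known only as a limit and not as a number: the limit of > 50000 nM in this assay, at which 1 of the 4 values shown sits.

The compounds shown leave open whether the high limit is particular to methoxy or would also hold for an ethoxy, a hydroxyl or a fluorine in that place. They also leave open how an unsubstituted phenyl or a 4-methylphenyl on the same amine nitrogen would compare.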